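Swapping fluorophenyl for nitrophenyl in a cell tolerance test

The source may hold more compounds than are shown below. What is called first, only, known or untested is meant among the compounds shown, and "the series" means these compounds.

- Compound 1 `CC(=O)Nc1ccc2oc(-c3ccnc(C(=O)N4CCC5(CC4)CN(C(c4ccccc4)c4nnn(C)n4)C5)c3)nc2c1`: > 50000 nM (a limit)
- Compound 2 `CC(=O)Nc1ccc2oc(-c3ccnc(C(=O)N4CCN(C(c5cccc(F)c5)c5nnn(C)n5)CC4)c3)nc2c1`: > 50000 nM (a limit)
- Compound 3 `CC(=O)Nc1ccc2oc(-c3ccnc(C(=O)N4CCN([C@@H](c5ccc(F)cc5)c5nnn(C)n5)CC4)c3)nc2c1`: > 200000 nM (a limit)

All three compounds were measured in an ADME assay on MDCK cells (Canis lupus familiaris) for cytotoxicity (a lower number here means that less compound is tolerated, a higher number that more compound is tolerated), and each result is a limit of the assay, not a number. Compound 2 gives > 50000 nM, which is a limit. It stands here: the limit of > 50000 nM in this assay, at which 2 of the 3 values shown sit. The only other level seen is this: the limit of > 200000 nM in this assay, at which 1 of the 3 values shown sits.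

Compound 4 `CC(=O)Nc1ccc2oc(-c3ccnc(C(=O)N4CCN(C(c5ccc([N+](=O)[O-])cc5)c5nnn(C)n5)CC4)c3)nc2c1` differs from compound 2 in one place, with 4-nitrophenyl in place of 3-fluorophenyl on a saturated chain carbon bound to an amine nitrogen in a ring and an aromatic carbon. Within the data shown here, no measured step shows what a swap of this kind does in this assay, so no change beyond the usual scatter is expected. The expected step of a number no higher from compound 2 to compound 4 (the limit leaves the size open) therefore stays small. Compound 4 is estimated at 50000 nM, with an expected range from 25000 nM to 200000 nM, and the result may well be a limit again.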

Compound 4, half-maximal cytotoxic concentration: > 50000 nM
Compound 4 was reported as a limit (the forecaster's own chance of this, stated with the estimate: 80%); the middle value lies on the limit itself.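

Compound 2 and compound 4 are both reported only as limits in this assay, so the step between them cannot be read. The compounds shown leave open how much compound the cells actually tolerate with 3-fluorophenyl or 4-nitrophenyl, and whether this swap changes that at all.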